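The source may hold more compounds than are shown below. What is called first, only, known or untested is meant among the compounds shown, and "the series" means these compounds.

Measured compounds:
compound 1 `O=Cc1cc(Br)c(O)c(O)c1Br` — a functional assay on HCT-116 cells (Homo sapiens) for cytotoxicity, read by MTT assay, with a stated time of 96 h; on this read-out lower numbers stand for stronger inhibition and higher numbers for weaker inhibition: "not determined" (no result reported)
compound 2 `COCc1cc(O)c(O)c(Br)c1Br` — this assay: 14100 nM
compound 3 `COc1cc(C=O)c(Br)c(Br)c1O` — this assay: "not determined" (no result reported)

In this assay compound 1 gives "not determined" (no result reported), so no single number places it among the others, and compound 3 likewise has no number in this assay. Within the data shown here, the only number in the set comes from compound 2, which in this assay gives 14100 nM. The step from compound 1 to compound 4 `CCCOCc1cc(Br)c(O)c(O)c1Br` replaces one group on the shared core: propoxymethyl in place of formyl on an aromatic carbon. Since compound 1 has no number in this assay, the size of this step cannot be read from the data; whether the propoxymethyl compound differs from the formyl compound beyond the usual scatter, and in which direction, is left open. What can be said rests on compound 2, a related methoxymethyl compound on a similar brominated dihydroxyphenyl core, whose weak result of 14100 nM suggests that compounds of this kind give high numbers in this assay. Compound 4 is therefore expected to give about 12000 nM, within a range from 3000 nM to 50000 nM.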

Compound 4, half-maximal inhibitory concentration: 800 nM
The estimate for compound 4 lay 15-fold (1.18 log units) above the measured number; measured number below the stated range.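

In this assay, among these compounds, compound 1 has no single number, so no step from it to compound 4 can be read. No measured evidence bearing on the result of compound 4 is available. The compounds shown leave open how propoxymethyl and formyl compare on the shared core in this assay and whether any difference lies beyond the usual scatter.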